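A few compounds are considered here, and "the series" means these few. Any claim that something is new, unique, unknown or untested is made for them only; others in the source may bear on it.

Working notes on the sulfone series

Compound 1 `O=S(=O)(/C=C/c1ccccn1)c1ccccc1F` is the reference point of the set. In an assay on U2OS cells for activation of nuclear factor erythroid 2-related factor 2 (Homo sapiens), read by beta-arrestin recruitment, with a stated time of 6 h (a lower number here means that less compound is needed, a higher number that more compound is needed for the effect), compound 1 gives 1050 nM. Compound 2 `O=S(=O)(/C=C/c1cccc(Cl)n1)c1ccccc1F` carries the change chloro in place of hydrogen on an aromatic carbon on the same core, and in this assay compound 2 gives 898 nM. For the measured compounds named here, the step of a 1.2-fold lower number from compound 1 to compound 2 (0.07 log units; within the scatter) is the only single-point change measured so far.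

Compound 3 `O=S(=O)(/C=C/c1ccccn1)c1ccc(Cl)cc1` has a different core; the difference between the two cores is not broken down here. In this assay compound 3 gives 1730 nM, a value that sits within the scatter of both compound 1 and compound 2, so no order among the three is drawn.

Compound 4 `O=S(=O)(/C=C/c1ccc(Cl)cn1)c1ccc(Cl)cc1` is not yet measured. It differs from compound 3 by chloro in place of hydrogen on an aromatic carbon. Going by the values given here, this is the same kind of change as the one from compound 1 to compound 2, not the same: there the chloro sits next to the ring nitrogen, meta to a large group, whereas here it sits two atoms from the ring nitrogen, para to a large group.

Given that the earlier step of a 1.2-fold lower number from compound 1 to compound 2 (0.07 log units; within the scatter) stayed within the scatter, the expected step for the new compound is likewise small, a 1.2-fold lower number from compound 3 to compound 4 (0.06 log units; within the scatter). Compound 4 is estimated at 1500 nM in this assay, with an expected range from 700 nM to 3500 nM; the wider range reflects that the place of the chloro differs from the measured precedent.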

Compound 4, half-maximal effective concentration: 3160 nM
Beside the measured number, compound 4's estimate is 2.1-fold (0.32 log units) below it; the range from low to high includes it.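

In this assay the new step is a 1.8-fold higher number from compound 3 to compound 4 (0.26 log units; within the scatter), so compound 3 and compound 4 are not told apart by this read-out. Set beside the earlier step on the other core, the new step does not differ from it: the same change on two cores in this assay, a 1.2-fold lower number (0.07 log units; within the scatter) from compound 1 to compound 2 and a 1.8-fold higher number (0.26 log units; within the scatter) from compound 3 to compound 4, 2.1-fold (0.33 log units) apart, within the scatter of two such steps This shows that chloro in place of hydrogen on an aromatic carbon gave no step beyond the scatter on either of these two cores, which is all that can be said of carrying it across; it does not show a fixed effect that transfers, as neither step can be told from no step at all, only two pairs are at hand, and the chloro of compound 4, two atoms from the ring nitrogen and para to a large group, stands in a different place from the chloro of compound 2.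

The compounds shown leave open whether chloro in one and the same place on both cores would give matching steps, and whether a group other than chloro on the six-membered aromatic ring with 1 nitrogen, such as an amine, a carboxylic acid or a methoxy group, would give a step beyond the scatter in this assay. They also leave open how far any of these results would hold on a core that carries neither the fluoro nor the chloro of the other aromatic ring.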